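Toxicity limits and a cyclopropyl swap on one core

A few compounds are considered here, and "the series" means these few. Any claim that something is new, unique, unknown or untested is made for them only; others in the source may bear on it.

In a toxicity assay on Vero cells (Chlorocebus sabaeus) for inhibition (a lower number here means that less compound is needed, a higher number that more compound is needed for the effect), compound 1 `COc1cccc(NC(=O)c2nnn(Cc3ccncc3)c2N)c1` gives only a limit, > 50100 nM. Compound 2 `COc1cccc(NC(=O)c2nnn(Cc3cc(C)on3)c2N)c1` also gives only a limit, > 50100 nM. Compound 3 `COc1cccc(NC(=O)c2nnn(Cc3ccc(-n4cccn4)cc3)c2N)c1` likewise gives only a limit, > 50100 nM. The whole record so far is the limit of > 50100 nM in this assay, at which 3 of the 3 values shown sit. Within the data shown here, the only measured step is a step that the two limits leave unreadable from compound 1 to compound 2, so it offers no size to carry over. Compound 4 `COc1cccc(NC(=O)c2nnn(Cc3ccc(C4CC4)cc3)c2N)c1` differs from compound 3 by cyclopropyl in place of 1H-pyrazol-1-yl on an aromatic carbon, with cyclopropyl in place of 1H-pyrazol-1-yl on an aromatic carbon. Among the measured compounds shown here, no step of readable size bears on this change, so no shift beyond the scatter is expected in this assay. The expected step is a step that the limit leaves unreadable from compound 3 to compound 4. For compound 4 the estimated value is 60000 nM, within an expected range of 25000 nM to 150000 nM.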

Compound 4, half-maximal effective concentration in the Vero assay: > 50100 nM
Compound 4 was reported as a limit; the forecaster's own chance of this, stated with the estimate: 85%; the middle value is on the limit's open side.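

In the Vero assay compound 4 gives only a limit, > 50100 nM, so its steps from compound 1, compound 2 and compound 3 cannot be read. On these data alone, the concentration at which any of these four compounds would reach the effect stays open: the limit of > 50100 nM in the Vero assay, at which 4 of the 4 values shown sit. In a physicochemical assay for lipophilicity, read by HPLC, measured as chromatographic lipophilicity, at pH 7.4 (a lower number here means a more polar compound, a higher number a more lipophilic compound), compound 3 gives 2.4 and compound 4 gives 3.2.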